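A few compounds are considered here, and "the series" means these few. Any claim that something is new, unique, unknown or untested is made for them only; others in the source may bear on it.

Measured so far in a functional assay, tested at 10 uM; on this read-out lower numbers stand for a weaker effect and higher numbers for a stronger effect at the one concentration tested:
compound 1 `O=C(Cn1c(=O)c(-c2ccc(O)c(O)c2)nc2ccccc21)NS(=O)(=O)C(F)(F)F` gives 81.4%
compound 2 `O=C(Cn1c(=O)c(/C=C/c2ccccc2)nc2ccccc21)NS(=O)(=O)C(F)(F)F` gives 6.4%
compound 3 `O=C(Cn1c(=O)c(/C=C/c2ccc(O)cc2)nc2ccccc21)NS(=O)(=O)C(F)(F)F` gives 13.2%

Compound 3 holds the second highest of the three numbers in this assay: its nearest neighbour is compound 2, and the two differ by a number 6.8 percentage points higher from compound 2 to compound 3 (within the scatter); the furthest is compound 1, which sits higher by a number 68.2 percentage points lower from compound 1 to compound 3 (beyond the scatter). Compound 4 `COc1cc(/C=C/c2nc3ccccc3n(CC(=O)NS(=O)(=O)C(F)(F)F)c2=O)ccc1O` is not yet measured. Relative to compound 3 the change is methoxy in place of hydrogen on an aromatic carbon.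

Among the compounds with values here, the step that bears most directly on this change is the one from compound 2 to compound 3, a number 6.8 percentage points higher from compound 2 to compound 3 (within the scatter), where a hydroxy on the same ring of the 2-phenylethenyl group moved the read-out by little. The large steps of a number 75 percentage points lower from compound 1 to compound 2 (beyond the scatter) and a number 68.2 percentage points lower from compound 1 to compound 3 (beyond the scatter) concern the exchange of the whole 3,4-dihydroxyphenyl group for an ethenyl-linked ring and do not speak to a methoxy alone. Within the 2-arylethenyl series, then, compound 4 is expected to stay near compound 3, with a step of a number 3.8 percentage points higher from compound 3 to compound 4 (within the scatter) that is not expected to exceed the scatter. Compound 4 is therefore estimated at 17% in this assay, in a range from 5% to 35%.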

Compound 4, a percentage reported as activity, at one concentration (the size of the read-out at that concentration, not a potency): 52.2%
Compound 4: middle estimate off by 35.2 percentage points, on the low side, outside the stated range (above it).
By their numbers in this assay, from the lowest: compounds 2 and 3 (each within the scatter of the next); then compound 4; then compound 1.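

In this assay, methoxy on the ring of the 2-(4-hydroxyphenyl)ethenyl group, ortho to a hydroxy group, gives a number 39 percentage points higher from compound 3 to compound 4 (beyond the scatter), whereas the hydroxy alone had given only a number 6.8 percentage points higher from compound 2 to compound 3 (within the scatter), so this ring responds strongly to a small added group once that hydroxy is present. The ethenyl-linked compounds are thus not confined to low numbers, as the full exchange of phenyl for 4-hydroxy-3-methoxyphenyl shows with a number 45.8 percentage points higher from compound 2 to compound 4 (beyond the scatter), yet the 3,4-dihydroxyphenyl group still stands ahead, with a number 29.2 percentage points lower from compound 1 to compound 4 (beyond the scatter). Nothing at hand explains the size of this gain.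

On these data alone, it remains open whether the methoxy keeps this effect without the neighbouring hydroxy. Whether an ethoxy group or a chlorine atom in its place would do the same is also unsettled.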